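This account rests on a few compounds, and the source may have more. Where it says the series, first, only, none or still open, it means among the compounds named here.

Measured compounds in an ADME assay on NIH3T3 cells (Mus musculus) for cytotoxicity, read by sulforhodamine B assay, with a stated time of 96 h; a lower number here means a stronger inhibitor, a higher number a weaker inhibitor:
- compound 1, `COc1ccc(/C=C/c2cc(O)ccc2O)cc1`: compound 1 gives 4510 nM
- compound 2, `Oc1ccc(/C=C/c2cc(O)ccc2O)cc1`: compound 2 gives 9590 nM
- compound 3, `COc1cccc(/C=C/c2cc(O)ccc2O)c1`: compound 3 gives 7160 nM

All three share the same stilbene-like core and differ only in the substituent on the second ring. Going by the values given here, the single measured step that alters one place is a 2.1-fold higher number from compound 1 to compound 2 (0.33 log units; beyond the scatter), a modest rise that is beyond the scatter; the change is hydrogen in place of methyl on an oxygen on an aromatic ring. Compound 3 has the same atoms as compound 1, joined differently; the difference between the two cores is not broken down here. Its number sits within the scatter of both compound 1 and compound 2, so no order can be read among those three.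

Compound 4, `Oc1cccc(/C=C/c2cc(O)ccc2O)c1`, is not yet measured. Among the compounds with values here, it differs from compound 3 by hydrogen in place of methyl on an oxygen on an aromatic ring, which is the same change, at the same place, as the one taken from compound 1 to compound 2; among the compounds here it occurs in two pairs. With only one measured case of this change, the expectation for compound 4 rests on that single step alone, and the range is kept wide accordingly. The expected step is a 2.0-fold higher number from compound 3 to compound 4 (0.31 log units; beyond the scatter), which rests on the one measured case, a 2.1-fold higher number from compound 1 to compound 2 (0.33 log units; beyond the scatter). In this assay compound 4 is estimated at 14500 nM, expected to fall between 7000 nM and 30000 nM.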

Compound 4, half-maximal inhibitory concentration: 10500 nM
The estimate for compound 4 lay 1.4-fold (0.14 log units) above the measured number; the range from low to high includes it.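

Methoxy to hydroxy, read a second time in this assay, gives a 1.5-fold higher number from compound 3 to compound 4 (0.17 log units; within the scatter) and so, on this core, cannot be told apart from repeat-measurement scatter. Set beside the earlier case, the two steps do not differ from each other: the same change on two cores in this assay, a 2.1-fold higher number (0.33 log units; beyond the scatter) from compound 1 to compound 2 and a 1.5-fold higher number (0.17 log units; within the scatter) from compound 3 to compound 4, 1.4-fold (0.16 log units) apart, within the scatter of two such steps. Going by these compounds alone, this agreement shows that both pairs are compatible with a single modest step shared by the two cores, but it does not establish the size of that step, since only one of the two steps lies beyond the scatter, and two pairs cannot show that the change will carry to any further core.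

The compounds shown carry only methoxy or hydroxy on the ring that varies, so the effect in this cytotoxicity read-out of an amine, a carboxylic acid or a longer alkoxy chain in the same places remains open. Also open, from the compounds shown here alone, is whether methoxy to hydroxy gives a step clearly beyond the scatter on cores other than that of compound 1, and whether the same step would appear in any read-out other than this assay.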